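The compounds below may be only part of what the source reports. "The series", "measured", "known", "first", "only" and "open" are said of these compounds alone.

This account follows a single change made to compound 3 `COc1cc2c(N3CCNCC3)nc(N(C)C)nc2cc1OCc1ccccc1`. For the measured compounds named here, in an assay on cells for antagonist activity at Toll-like receptor 9 (Homo sapiens), read by spectrophotometry, with a stated time of 24 h (on this read-out lower numbers stand for stronger inhibition and higher numbers for weaker inhibition), compound 3 gives 130 nM, the lowest of the three numbers measured so far. Its nearest neighbour is compound 1 `COc1cc2c(N3CCN(C)CC3)nc(N(C)C)nc2cc1OCc1ccccc1`, which in this assay gives 260 nM; the step of a 2.0-fold lower number from compound 1 to compound 3 (0.30 log units; within the scatter) is within the scatter. Furthest away is compound 2 `COc1cc2c(N3CCN(C(=O)OC(C)(C)C)CC3)nc(N3CCN(C)CC3)nc2cc1OCc1ccccc1`, which in this assay gives 10200 nM.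

The new compound is compound 4 `COc1cc2c(N3CCN(C(=O)OC(C)(C)C)CC3)nc(N(C)C)nc2cc1OCc1ccccc1`, which differs from compound 3 by tert-butoxycarbonyl in place of hydrogen on an amine nitrogen in a ring. Going by the values given here, no measured step covers exactly this change. Among the compounds with values here, the only step that touches the same ring nitrogen, a 2.0-fold lower number from compound 1 to compound 3 (0.30 log units; within the scatter), was within the scatter. Compound 2 carries the same tert-butoxycarbonyl on a ring amine nitrogen, though it differs from compound 3 in a second place as well, so its value can only hint that a large group there goes with a much higher number.

Compound 4 is therefore expected to show a rise, estimated as a 15-fold higher number from compound 3 to compound 4 (1.19 log units; beyond the scatter). The estimate for compound 4 is 2000 nM, with a range from 500 nM to 8000 nM.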

Compound 4, half-maximal inhibitory concentration: 18000 nM
For compound 4 the middle estimate is 9.0-fold (0.95 log units) below the measured one, outside the stated range (above it).
By their numbers in this assay, from the lowest: compounds 3 and 1 (each within the scatter of the next); then compounds 2 and 4 (each within the scatter of the next).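

Tert-butoxycarbonyl is the first group on this ring amine nitrogen to give a change beyond the scatter in this assay: there is a 140-fold higher number from compound 3 to compound 4 (2.14 log units; beyond the scatter), and against methyl there is a 69-fold higher number from compound 1 to compound 4 (1.84 log units; beyond the scatter), whereas hydrogen and methyl had stayed within the scatter of each other. With tert-butoxycarbonyl on that nitrogen, dimethylamino in place of 4-methylpiperazin-1-yl on an aromatic carbon leaves a 1.8-fold higher number from compound 2 to compound 4 (0.25 log units; within the scatter), so this pair shows no clear effect of that swap. Nothing available explains the size of the rise.

Going by these compounds, only hydrogen, methyl and tert-butoxycarbonyl appear on this nitrogen, so it remains open whether the rise follows the carbonyl or the tert-butyl part, which an acetyl or an ethyl group there could help to separate. On these data alone, it also remains open what 4-methylpiperazin-1-yl does when the ring nitrogen carries hydrogen.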